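Shortening the nitrile chain on the ring nitrogen

The source may report more compounds than this note shows. Statements on the series, on what has been measured and on what is new or still open speak of the compounds shown alone.

Compound 1 `COc1ccc(-c2cc3c(OC)cc(OC)cc3n(C)c2=O)cc1` carries a methyl on the ring nitrogen of the shared core; in a functional assay on A549 cells (Homo sapiens) for cytotoxicity, read by colorimetric assay and MTT assay (on this read-out lower numbers stand for stronger inhibition and higher numbers for weaker inhibition), compound 1 gives 10000 nM. Compound 2 `COc1ccc(-c2cc3c(OC)cc(OC)cc3n(CCCC#N)c2=O)cc1` carries a 3-cyanopropyl chain instead, and in this assay compound 2 gives 10000 nM. The step of no change at the digits printed from compound 1 to compound 2 (within the scatter) shows that the chain added no measurable effect. Among the measured compounds shown here, compound 2 therefore stands level with compound 1 on the numbers so far, with no spread to speak of.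

Compound 3 `COc1ccc(-c2cc3c(OC)cc(OC)cc3n(CCC#N)c2=O)cc1` differs from compound 2 by cyano in place of cyanomethyl on a saturated chain carbon, two bonds along the chain from an aromatic nitrogen. For the measured compounds named here, only one measured step bears on this change, and it was flat; both measured compounds sit at the same value. No step beyond the scatter in this assay is expected in either direction. Compound 3 is expected to give 10000 nM, estimated between 5000 nM and 20000 nM. The expected step is estimated as no change at the digits printed from compound 2 to compound 3 (within the scatter).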

Compound 3, half-maximal inhibitory concentration: 10000 nM
Compound 3: middle estimate and measured number agree at the digits printed; the range from low to high includes it.
By their numbers in this assay, from the lowest: compounds 1, 2 and 3 (each within the scatter of the next).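

Shortening the chain on the ring nitrogen from 3-cyanopropyl to 2-cyanoethyl gives no change at the digits printed from compound 2 to compound 3 (within the scatter) in this assay, so a second nitrile chain length now reads the same as the first. Against the methyl of compound 1, the shorter chain gives no change at the digits printed from compound 1 to compound 3 (within the scatter), which puts methyl, 2-cyanoethyl and 3-cyanopropyl at one level in this assay and leaves this position with no spread among the three compounds. No measurement on hand accounts for this flat reading.

From the compounds shown here alone, whether any group on the ring nitrogen moves the value away from this level stays open; a carboxylic acid or an amine at the chain end, or a chain longer than 3-cyanopropyl, would test that. The methoxy groups on the shared core are the same in all three compounds, so what they contribute cannot be read from this series.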